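Replacing the Five-Membered Ring of Compound 3

A few compounds are considered here, and "the series" means these few. Any claim that something is new, unique, unknown or untested is made for them only; others in the source may bear on it.

In a functional assay on Coronary artery (Bos taurus) (a lower number here means that less compound is needed, a higher number that more compound is needed for the effect), compound 1 `CCCCCNC(=O)NCCCC/C=C\CCCCCNS(=O)(=O)c1ccccc1` gives 3400 nM, compound 2 `CCCCCNC(=O)NCCCC/C=C\CCCCCSc1nnn[nH]1` gives 3700 nM and compound 3 `CCCCCNC(=O)NCCCC/C=C\CCCCCCC1=NOS(=O)N1` gives 340 nM, the lowest number of the three. Compound 4 `CCCCCNC(=O)NCCCC/C=C\CCCCCCc1nsc(=O)[nH]1` is still unmeasured. Its change is a group of 6 heavy atoms (2 carbon, 2 nitrogen, 1 oxygen, 1 sulfur; one five-membered aromatic ring with 3 hetero atoms) in place of a group of 6 heavy atoms (1 carbon, 2 nitrogen, 2 oxygen, 1 sulfur; one five-membered non-aromatic ring with 4 hetero atoms), on a saturated chain carbon, six bonds along the chain from a double-bonded chain carbon: a five-membered aromatic ring with 3 hetero atoms replaces a five-membered non-aromatic ring with 4 hetero atoms, on a saturated chain carbon, six bonds along the chain from a double-bonded chain carbon.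

For the measured compounds named here, no measured compound carries the new ring, so the evidence is indirect. Exchanging this group gave a 10-fold lower number from compound 1 to compound 3 (1.00 log units; beyond the scatter) and an 11-fold lower number from compound 2 to compound 3 (1.04 log units; beyond the scatter), yet also a 1.1-fold higher number from compound 1 to compound 2 (0.04 log units; within the scatter), which stays within the scatter. The group can therefore matter, but not every exchange does. Since compound 3 holds the lowest number at 340 nM, a modest move to a higher number is expected, smaller than the two large steps. The expected step is a 2.4-fold higher number from compound 3 to compound 4 (0.37 log units; beyond the scatter). For compound 4 the estimated value is 800 nM, with an expected range from 200 nM to 3000 nM.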

Compound 4, half-maximal effective concentration: 2400 nM
Beside the measured number, compound 4's estimate is 3.0-fold (0.48 log units) below it; measured number inside the range.
By their numbers in this assay, from the lowest: compound 3; then compounds 4, 1 and 2 (each within the scatter of the next).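

In this assay, this position proves sensitive even to an exchange that leaves the heavy atom, hydrogen-bond donor and hydrogen-bond acceptor counts unchanged, as the five-membered aromatic ring with 3 hetero atoms gives (a 7.1-fold higher number from compound 3 to compound 4 (0.85 log units; beyond the scatter)). Compound 4 stays within the scatter of the two earlier compounds that carry other groups (a 1.5-fold lower number from compound 2 to compound 4 (0.19 log units; within the scatter); a 1.4-fold lower number from compound 1 to compound 4 (0.15 log units; within the scatter)), so a third group joins them and compound 3 alone stands apart. No measurement shown explains why the five-membered non-aromatic ring with 4 hetero atoms stands apart.

Going by these compounds, whether a carboxylic acid on the same saturated chain carbon would reach the low number of compound 3 remains open. So does whether the ring of compound 3 would keep that number on a longer chain.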